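Swapping Chloro for Trifluoromethyl: Expected Stability of Compound 4

The source may hold more compounds than are shown below. What is called first, only, known or untested is meant among the compounds shown, and "the series" means these compounds.

Measured compounds:
- compound 1 `N#Cc1cnc(NC(=O)CCCOc2cccc(Cl)c2)s1`: 0.25 h
- compound 2 `Cc1cnc(NC(=O)CCCOc2cccc(C#N)c2)s1`: 0.167 h
- compound 3 `Cc1cnc(NC(=O)NCCOc2ccc(Cl)c(C)c2)s1`: 0.267 h

Of the compounds shown here, three have been measured in an ADME assay on microsomes from liver (Homo sapiens) for metabolic stability, read by LC-MS, using NADPH, tested at 1 uM; a lower number here means that the compound disappears faster, a higher number that the compound lasts longer. Among the three numbers, compound 1 stands second highest. Its nearest neighbour is compound 3, and the furthest is compound 2, but both of those gaps fall within the usual scatter of repeated measurements, so the three compounds cannot be ordered against one another on these numbers alone; all three disappear within well under an hour.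

Compound 4 `N#Cc1cnc(NC(=O)CCCOc2cccc(C(F)(F)F)c2)s1` has not yet been measured. It differs from compound 1 in a single place: trifluoromethyl in place of chloro on an aromatic carbon. Going by the values given here, no two measured compounds differ in just one place, so there is no measured step to borrow from for the size of this change. In the absence of such a precedent, the step is expected to be small, no larger than the scatter, in either direction: a 1.2-fold higher number from compound 1 to compound 4 (0.08 log units; within the scatter). Compound 4 is therefore estimated at 0.3 h, with a likely range from 0.12 h to 0.7 h.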

Compound 4, half-life in the Homo sapiens assay: 1.33 h
Estimate against measurement, compound 4: 4.4-fold (0.65 log units) below; measured number above the stated range.
By their numbers in the Homo sapiens assay, from the lowest: compounds 2, 1 and 3 (each within the scatter of the next); then compound 4.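

Going by these compounds alone, in the Homo sapiens assay, trifluoromethyl in place of chloro on an aromatic carbon gives a 5.3-fold higher number from compound 1 to compound 4 (0.73 log units; beyond the scatter), so this one change on the ring moves the half-life beyond the scatter, which the earlier compounds, none differing from another in just one place, could not show. In a physicochemical assay for solubility, read by nephelometry, in phosphate buffer, at pH 6.5 (on this read-out lower numbers stand for lower solubility and higher numbers for higher solubility), compound 1 gives < 1600 nM, which is a limit of the assay and not a number. In the physicochemical assay compound 4 gives < 1600 nM, which is also a limit of the assay.

The step between these two compounds in the physicochemical assay cannot be read: the limit of < 1600 nM in the physicochemical assay, at which 2 of the 2 values shown sit. Still open is whether other groups at this place, such as an amine or a carboxylic acid, would shift the half-life in the same direction, and whether this change would do the same on the other compounds shown.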